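A few compounds are considered here, and "the series" means these few. Any claim that something is new, unique, unknown or untested is made for them only; others in the source may bear on it.

Measured in a functional assay on MCF7 cells (Homo sapiens) for antiproliferative activity, read by MTT assay, with a stated time of 72 h; on this read-out lower numbers stand for stronger inhibition and higher numbers for weaker inhibition:
- compound 1 `CCNc1cc(C)c2cc(NC(=O)c3ccc(Cl)c(Cl)c3)ccc2n1`: 48600 nM
- compound 2 `CCN(CC)c1cc(C)c2cc(NC(=O)c3ccc(Cl)c(Cl)c3)ccc2n1`: > 50000 nM
- compound 3 `Cc1cc(N2CCCCC2)nc2ccc(NC(=O)c3ccc(Cl)c(Cl)c3)cc12`: 31100 nM

The entry of compound 2 is a limit of the assay and not a number. That leaves two numbers in the series, and they lie within the scatter of each other, with a 1.6-fold lower number from compound 1 to compound 3 (0.19 log units; within the scatter). Compound 3, at 31100 nM, therefore cannot be separated from compound 1.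

Compound 4 `Cc1cc(N2CCN(C)CC2)nc2ccc(NC(=O)c3ccc(Cl)c(Cl)c3)cc12` carries 4-methylpiperazin-1-yl in place of piperidin-1-yl on an aromatic carbon, next to the ring nitrogen (4-methylpiperazin-1-yl in place of piperidin-1-yl on an aromatic carbon). For the measured compounds named here, three measured steps bear on this change, as all alter the amine on that same carbon. Besides the step already given, they are an at least 1.0-fold higher number from compound 1 to compound 2 (0.01 log units; that floor lies within the scatter) and an at least 1.6-fold lower number from compound 2 to compound 3 (0.20 log units; that floor lies within the scatter). None goes beyond the scatter, and the two involving compound 2 rest on a limit. Going by the values given here, no measured compound yet carries 4-methylpiperazin-1-yl, so this reading is only an extrapolation.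

With that caution, no step beyond the scatter is expected in this assay. The estimated step is a 1.0-fold lower number from compound 3 to compound 4 (0.02 log units; within the scatter). For compound 4 the estimated value is 30000 nM. The range expected for compound 4 runs from 13000 nM to 50000 nM.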

Compound 4, half-maximal inhibitory concentration: 3000 nM
Beside the measured number, compound 4's estimate is 10-fold (1.00 log units) above it, and the stated range ends above it.
By their numbers in this assay, from the lowest: compound 4; then compounds 3 and 1 (each within the scatter of the next). At a limit, above all of these: compound 2.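

In this assay, for the compounds shown here, the amines on this aromatic carbon next to the ring nitrogen had so far given no step beyond the scatter, so the position looked insensitive to the change of amine; 4-methylpiperazin-1-yl ends that reading, with a 10-fold lower number from compound 3 to compound 4 (1.02 log units; beyond the scatter), although it differs from piperidin-1-yl only in having a six-membered ring with 2 hetero atoms and one more heavy atom. The same group also stands clear of the ethylamino compound, with a 16-fold lower number from compound 1 to compound 4 (1.21 log units; beyond the scatter), so the effect appears against both a ring amine and an open-chain amine. Against diethylamino the result is an at least 16-fold lower number from compound 2 to compound 4 (1.22 log units; beyond the scatter), and this size is only a floor, since compound 2 stands at a limit of the assay: the limit of > 50000 nM in this assay, at which 1 of the 4 values shown sits.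

The compounds shown leave open whether the step belongs to the second ring nitrogen, to the methyl group on it, or to both, and the values themselves give no cause for it. Piperazin-1-yl without the methyl group, morpholin-4-yl with an oxygen in that ring place, and 4-ethylpiperazin-1-yl with a longer chain on the nitrogen would begin to separate these readings.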